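A few compounds are considered here, and "the series" means these few. Any claim that something is new, unique, unknown or untested is made for them only; others in the source may bear on it.

Of the compounds shown here, three share one core and have been tested so far. Compound 1 `COc1ccc(C(=O)/C=C/c2cc(-c3cc(OC)c(OC)c(OC)c3)n3nc(-c4ccccc4)cc3n2)cc1` gives 79800 nM in an ADME assay on HEK293 cells (Homo sapiens) for antiproliferative activity, read by MTT assay, with a stated time of 24 h; a higher number here means a weaker inhibitor, a lower number a stronger inhibitor. Compound 2 `COc1ccc(-c2cc(/C=C/C(=O)c3ccc(OC)c(OC)c3)nc3cc(-c4ccccc4)nn23)cc1` gives 48500 nM in this assay. Compound 3 `COc1ccc(C(=O)/C=C/c2cc(-c3ccc(OC)c(OC)c3)n3nc(-c4ccccc4)cc3n2)cc1` gives 40000 nM in this assay, the lowest of the three numbers, though its gaps to compound 2 and to compound 1 both fall within the scatter. For the measured compounds named here, the only measured step of the same kind is a 2.0-fold lower number from compound 1 to compound 3 (0.30 log units; within the scatter), a removal of one methoxy group that stayed within the scatter. Compound 4 `COc1ccc(C(=O)/C=C/c2cc(-c3ccc(OC)cc3)n3nc(-c4ccccc4)cc3n2)cc1` repeats such a removal: hydrogen in place of methoxy on an aromatic carbon. On that single precedent no shift beyond the scatter is expected in this assay, so the expected step is a 1.1-fold higher number from compound 3 to compound 4 (0.05 log units; within the scatter). Compound 4 is therefore estimated at 45000 nM, between 22000 nM and 95000 nM.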

Compound 4, half-maximal inhibitory concentration: 36100 nM
For compound 4 the middle estimate is 1.2-fold (0.10 log units) above the measured one; the measured number falls inside the stated range.
By their numbers in this assay, from the lowest: compounds 4, 3, 2 and 1 (each within the scatter of the next, the first and the last beyond it).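

In this assay the step of a 1.1-fold lower number from compound 3 to compound 4 (0.04 log units; within the scatter) shows that a second methoxy group can leave this ring with no change beyond the scatter, and the step of a 1.3-fold lower number from compound 2 to compound 4 (0.13 log units; within the scatter) shows the same for this swap on a different ring. Only the two removals together, a 2.2-fold lower number from compound 1 to compound 4 (0.34 log units; beyond the scatter) and modest in size, pass beyond the scatter. For the compounds shown here, the single swap reads alike in both settings: the same change on two cores in this assay, a 2.0-fold lower number (0.30 log units; within the scatter) from compound 1 to compound 3 and a 1.3-fold lower number (0.13 log units; within the scatter) from compound 2 to compound 4, 1.5-fold (0.17 log units) apart, within the scatter of two such steps.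

Open, as far as these compounds go, is what happens when the last methoxy group on this ring leaves, or when a hydroxyl group, an amine or a carboxylic acid stands here instead.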